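The compounds below may be only part of what the source reports. "The series", "measured", "known", "first", "only" and "open" are said of these compounds alone.

Measured so far in a functional assay on MV4-11 cells (Homo sapiens) for antiproliferative activity, read by luminescence and CellTiter-Glo, with a stated time of 72 h; on this read-out lower numbers stand for stronger inhibition and higher numbers for weaker inhibition:
compound 1 `COc1ccc(Cn2nc(Nc3cccc(C(C)C)c3)c3ccc(-c4c(C)noc4C)cc32)cc1` gives 8100 nM
compound 2 `CNc1cc(-c2ccc3cnn(Cc4ccc(F)cc4)c3c2)cn(C)c1=O` gives 2390 nM
compound 3 `CNc1cc(-c2ccc3cnn(Cc4ccc(OC)cc4)c3c2)cn(C)c1=O` gives 2700 nM

Compound 3 at 2700 nM lies within the scatter of compound 2 at 2390 nM and stands lower, beyond the scatter, than compound 1 at 8100 nM.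

The next compound is compound 4 `CNc1cc(-c2ccc3cnn(Cc4ccc(C)cc4)c3c2)cn(C)c1=O`, with methyl in place of methoxy on an aromatic carbon, para to a large group, so that 4-methoxybenzyl becomes 4-methylbenzyl: methyl in place of methoxy on an aromatic carbon.

Among the compounds with values here, one measured step bears on this place: a 1.1-fold higher number from compound 2 to compound 3 (0.05 log units; within the scatter), with methoxy in place of fluoro on an aromatic carbon. Within the data shown here, that step stays within the scatter, but it is the only evidence, and no methyl compound has been measured. No step beyond the scatter is therefore expected in this assay, and no direction is favoured.

The expected change is a 1.1-fold lower number from compound 3 to compound 4 (0.03 log units; within the scatter).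

For compound 4 the estimated value is 2500 nM, with an expected range of 1300 nM to 4800 nM.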

Compound 4, half-maximal inhibitory concentration: 3280 nM
For compound 4 the middle estimate is 1.3-fold (0.12 log units) below the measured one, and the stated range covers the measured number.
By their numbers in this assay, from the lowest: compounds 2, 3 and 4 (each within the scatter of the next); then compound 1.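

In this assay, the aromatic carbon para to a large group now carries a third group, and a methyl there gives a 1.2-fold higher number from compound 3 to compound 4 (0.08 log units; within the scatter) and a 1.4-fold higher number from compound 2 to compound 4 (0.14 log units; within the scatter). Replacing 4-methoxybenzyl with 4-methylbenzyl removes the oxygen and the one hydrogen-bond acceptor of the methoxy group, yet the number stays within the scatter, so methyl, methoxy and fluoro cannot be told apart at this place. No measurement at hand accounts for this sameness.

As far as these compounds go, it remains open whether an amine, a carboxylic acid or a longer chain at this place would move the number beyond the scatter. From the compounds shown here alone, it is also open whether the same methyl, methoxy and fluoro groups would read alike on the core of compound 1.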